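The compounds below may be only part of what the source reports. "The series", "measured", "known", "first", "only" and "open" are said of these compounds alone.

Measured in a functional assay on Hep 3B2 cells (Homo sapiens) for cytotoxicity, read by MTT assay; on this read-out higher numbers stand for weaker inhibition and lower numbers for stronger inhibition:
- Compound 1 `CCOc1ccc(O)c(C(=O)/C=C/c2ccc(C)s2)c1`: 90200 nM
- Compound 2 `Cc1ccc(/C=C/C(=O)c2cc(OC(C)C)ccc2O)s1`: 81700 nM

Among the compounds with values here, compound 1 stands within the scatter of compound 2, the only other measured compound. Compound 3 `Cc1ccc(/C=C/C(=O)c2cc(OCC(C)C)ccc2O)s1` is not yet measured. It differs from compound 1 by isopropyl in place of methyl on a saturated chain carbon bound to an oxygen on an aromatic ring. Within the data shown here, one measured step bears on this change, a smaller change at the same place: a 1.1-fold lower number from compound 1 to compound 2 (0.04 log units; within the scatter). On that single step, no change beyond the scatter is expected in this assay. The estimated step is a 1.2-fold lower number from compound 1 to compound 3 (0.08 log units; within the scatter). For compound 3 the expected value is 75000 nM, with an estimated range of 38000 nM to 130000 nM.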

Compound 3, half-maximal inhibitory concentration: 54400 nM
For compound 3 the middle estimate is 1.4-fold (0.14 log units) above the measured one; measured number inside the range.
By their numbers in this assay, from the lowest: compounds 3, 2 and 1 (each within the scatter of the next).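

Going further out on the chain at this place, from ethoxy to isobutoxy, gives in this assay a 1.7-fold lower number from compound 1 to compound 3 (0.22 log units; within the scatter). The step from isopropyl to isobutyl on the oxygen on the aromatic ring gives a 1.5-fold lower number from compound 2 to compound 3 (0.18 log units; within the scatter). So even with the larger isobutyl group, no step among these three compounds goes beyond the scatter, and no measurement at hand offers an explanation for this.

As far as these compounds go, whether an amine, a carboxylic acid or a much longer chain on this oxygen would shift the number beyond the scatter remains open. So does the effect of a ring there.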